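Changing the hydrazone aryl group of a thiazole acylurea

The source may report more compounds than this note shows. Statements on the series, on what has been measured and on what is new or still open speak of the compounds shown alone.

Of the compounds shown here, three have been measured in a functional assay on HepG2 cells (Homo sapiens) for inhibition, read by MTT assay, with a stated time of 72 h; a lower number here means a stronger inhibitor, a higher number a weaker inhibitor. Compound 1 `CN(C(=O)NC(=O)c1cccc(C(F)(F)F)c1)c1nc(C(F)(F)F)c(C(=O)N/N=C/c2ccc(C(F)(F)F)cc2)s1` gives 7.71 ug/mL. Compound 2 `CN(C(=O)NC(=O)c1c(F)cccc1F)c1nc(C(F)(F)F)c(C(=O)N/N=C/c2cccc(C(F)(F)F)c2)s1` gives 27.9 ug/mL, and compound 3 `Cc1nc(N(C)C(=O)NC(=O)c2c(F)cccc2F)sc1C(=O)N/N=C/c1cccc(C(F)(F)F)c1` gives 31.6 ug/mL, the highest of the three numbers. Going by the values given here, the only single-point comparison among them is a 1.1-fold higher number from compound 2 to compound 3 (0.05 log units; within the scatter). Compound 1 and compound 3 differ in more than one place, so their two values show only a gap, with compound 1 beyond the scatter on the lower side.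

Compound 4 `Cc1nc(N(C)C(=O)NC(=O)c2c(F)cccc2F)sc1C(=O)N/N=C/c1ccc(Cl)cc1Cl` differs from compound 3 by 2,4-dichlorophenyl in place of 3-(trifluoromethyl)phenyl on a carbon with a double bond to nitrogen. Among the compounds with values here, no measured step touches this position; the one step known concerns a group on the shared core and lies within the scatter. There is thus no basis for expecting a shift in either direction in this assay beyond the scatter, though the uncertainty is wide. Compound 4 is expected at 30 ug/mL, within a range of 10 ug/mL to 90 ug/mL. This estimate means a step of a 1.1-fold lower number from compound 3 to compound 4 (0.02 log units; within the scatter), expected to remain within the scatter.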

Compound 4, half-maximal inhibitory concentration: 70 ug/mL
For compound 4 the middle estimate is 2.3-fold (0.37 log units) below the measured one; measured number inside the range.
By their numbers in this assay, from the lowest: compound 1; then compounds 2 and 3 (each within the scatter of the next); then compound 4.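

In this assay the hydrazone aryl group proves able to move the number: the change from 3-(trifluoromethyl)phenyl to 2,4-dichlorophenyl gives a 2.2-fold higher number from compound 3 to compound 4 (0.35 log units; beyond the scatter) and so a weaker inhibitor. The only earlier step, a methyl in place of trifluoromethyl on the shared core, stayed within the scatter, so this is the first single-place change shown to exceed it. No available evidence accounts for this shift.

Because the change removes one substituted aryl group and introduces another, the compounds shown cannot separate the contribution of the trifluoromethyl group from that of either chlorine. From the compounds shown here alone, whether a phenyl group carrying a single chlorine, an amine or a carboxylic acid would give a lower or higher number at this position remains open.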